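Trifluoromethyl in place of fluoro on compound 2

This account rests on a few compounds, and the source may have more. Where it says the series, first, only, none or still open, it means among the compounds named here.

Measured so far in a functional assay on A549 cells (Homo sapiens) for antiproliferative activity, read by MTT assay, with a stated time of 24 h; a higher number here means a weaker inhibitor, a lower number a stronger inhibitor:
compound 1 `O=S(=O)(c1ccccc1)n1c(-c2cn(-c3ccccc3)nc2-c2ccc(F)cc2)nc2ccccc21` gives 550 nM here
compound 2 `O=S(=O)(c1ccc(F)cc1)n1c(-c2cn(-c3ccccc3)nc2-c2ccc(F)cc2)nc2ccccc21` gives 2370 nM here
compound 3 `O=S(=O)(c1ccc(C(F)(F)F)cc1)n1c(-c2cn(-c3ccccc3)nc2-c2ccc(F)cc2)nc2ccccc21` gives 1280 nM here

Compound 2 sits at the upper end of these values, not separable from compound 3 and clear of compound 1, with a 4.3-fold higher number from compound 1 to compound 2 (0.63 log units; beyond the scatter) on record. Compound 4 `O=S(=O)(c1ccc(F)cc1)n1c(-c2cn(-c3ccccc3)nc2-c2ccc(C(F)(F)F)cc2)nc2ccccc21` is still unmeasured. It carries 4-(trifluoromethyl)phenyl where compound 2 has 4-fluorophenyl (trifluoromethyl in place of fluoro on an aromatic carbon), which is trifluoromethyl in place of fluoro on an aromatic carbon.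

Within the data shown here, the closest precedent is the same exchange on another aromatic ring, a 1.9-fold lower number from compound 2 to compound 3 (0.27 log units; within the scatter) in size. On that ring, a 2.3-fold higher number from compound 1 to compound 3 (0.37 log units; beyond the scatter) is also on record. Among the measured compounds shown here, no measured step touches the ring that changes in compound 4, so these steps guide only indirectly. In this assay, as far as these compounds go, no step beyond the scatter is expected, and the direction stays open. The expected step is a 1.2-fold lower number from compound 2 to compound 4 (0.10 log units; within the scatter) on this reasoning. For compound 4 the estimated value is 1900 nM with an expected range of 700 nM to 5000 nM for now.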

Compound 4, half-maximal inhibitory concentration: 1740 nM
Beside the measured number, compound 4's estimate is 1.1-fold (0.04 log units) above it; measured number inside the range.
By their numbers in this assay, from the lowest: compound 1; then compounds 3, 4 and 2 (each within the scatter of the next).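

In this assay, among these compounds, the change from 4-fluorophenyl to 4-(trifluoromethyl)phenyl gives the first reading on this ring, and the step (a 1.4-fold lower number from compound 2 to compound 4 (0.13 log units; within the scatter)) stays within the scatter, so compound 4 cannot be separated from compound 2. Trifluoromethyl in place of fluoro on an aromatic carbon has now been read on two rings, and the earlier step on the other ring (a 1.9-fold lower number from compound 2 to compound 3 (0.27 log units; within the scatter)) is also within the scatter, so in these two pairs the exchange gives no separable change. No measurement at hand accounts for this result.

The compounds shown leave open how an amine or a carboxylic acid would read in place of trifluoromethyl at this position. With only fluoro and trifluoromethyl seen here, they also leave open whether any group at this position gives a step beyond the scatter.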